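Replacing a Cyanobenzyl Group with a Small Ketone Chain

The source may hold more compounds than are shown below. What is called first, only, known or untested is meant among the compounds shown, and "the series" means these compounds.

Compound 2 `CCN(CC)c1ccc2cc(C(=O)c3ccc(N4CCN(C(=O)CN5CCN(Cc6ccc(C#N)cc6)CC5)CC4)cc3)oc2c1` gives the higher of two numbers in a functional assay on SGC-7901 cells (Homo sapiens) for cytotoxicity, read by MTT assay, with a stated time of 48 h (a higher number here means a weaker inhibitor, a lower number a stronger inhibitor), at 26300 nM. Compound 1 `CCN(CC)c1ccc2cc(C(=O)c3ccc(N4CCN(C(=O)CN5CCN(C(=O)/C=C/c6ccccc6)CC5)CC4)cc3)oc2c1` gives 1140 nM. Going by the values given here, the one measured step, a 23-fold higher number from compound 1 to compound 2 (1.36 log units; beyond the scatter), concerns a different exchange of groups on an amine nitrogen in a ring. Compound 3 `CCN(CC)c1ccc2cc(C(=O)c3ccc(N4CCN(C(=O)CN5CCN(CC(C)=O)CC5)CC4)cc3)oc2c1` differs from compound 2 by acetyl in place of 4-cyanophenyl on a saturated chain carbon bound to an amine nitrogen in a ring. Among the compounds with values here, no measured step tests this change, so the step of a 1.1-fold higher number from compound 2 to compound 3 (0.06 log units; within the scatter) is expected to stay within the scatter, with wide uncertainty. Compound 3 is therefore expected to give 30000 nM in this assay, within a broad range from 8000 nM to 100000 nM.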

Compound 3, half-maximal inhibitory concentration: 2210 nM
For compound 3 the middle estimate is 14-fold (1.13 log units) above the measured one, and the stated range ends above it.
By their numbers in this assay, from the lowest: compounds 1 and 3 (each within the scatter of the next); then compound 2.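

In this assay, the aromatic 4-cyanophenyl is not required on this saturated chain carbon: with the much smaller acetyl in its place, the result is a 12-fold lower number from compound 2 to compound 3 (1.08 log units; beyond the scatter). The 2-oxopropyl group, which has no ring, also stands level with (2-phenylethenyl)carbonyl on the amine nitrogen in a ring, at a 1.9-fold higher number from compound 1 to compound 3 (0.29 log units; within the scatter). No available evidence explains this difference. The compounds shown leave open whether the nitrile, the benzene ring or the ketone carbonyl accounts for the gap. A plain benzyl group and a simple propyl chain would help separate these parts.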